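The source may hold more compounds than are shown below. What is called first, only, known or untested is meant among the compounds shown, and "the series" means these compounds.

Of the compounds shown here, three of a shared core have been measured in a functional assay on HCT-116 cells (Homo sapiens) for antiproliferative activity, read by sulforhodamine B assay, with a stated time of 72 h; on this read-out lower numbers stand for stronger inhibition and higher numbers for weaker inhibition. Compound 1 `CCCCS(=O)(=O)Nc1cc(-c2ccc3ncnc(NCCN(C)C)c3c2)cnc1OC` gives 160 nM. Compound 2 `COc1ncc(-c2ccc3ncnc(NCCN(C)C)c3c2)cc1NS(=O)(=O)c1ccc(F)cc1F` gives 1440 nM. Compound 3 `COc1ncc(-c2ccc3ncnc(NCCCN(C)C)c3c2)cc1NS(=O)(=O)c1ccc(F)cc1F` gives 2200 nM.

Compound 1 differs from compound 2 by one change (butyl in place of 2,4-difluorophenyl on a sulfonyl sulfur), and this change brings a 9.0-fold lower number from compound 2 to compound 1 (0.95 log units; beyond the scatter). Compound 3 differs from compound 2 at the chain on the aromatic nitrogen ((dimethylamino)methyl in place of dimethylamino on a saturated chain carbon, two bonds along the chain from a nitrogen on an aromatic ring), and this change brings a 1.5-fold higher number from compound 2 to compound 3 (0.18 log units; within the scatter). Compound 3 thus stands as the highest of the three numbers, though its gap to compound 2 is within the scatter.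

Compound 4 `CCCCS(=O)(=O)Nc1cc(-c2ccc3ncnc(NCCCN(C)C)c3c2)cnc1OC` has not yet been measured in this assay. It differs from compound 3 by butyl in place of 2,4-difluorophenyl on a sulfonyl sulfur, which is the same change made from compound 2 to compound 1, at the same place. Compound 4 is therefore expected to show a step of an 8.8-fold lower number from compound 3 to compound 4 (0.94 log units; beyond the scatter), judged against the earlier step, because the measured pair gave a 9.0-fold lower number from compound 2 to compound 1 (0.95 log units; beyond the scatter) and compound 2 sits close to compound 3, which gives 2200 nM. On that basis compound 4 is estimated at 250 nM, with a range expected from 100 nM to 600 nM.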

Compound 4, half-maximal inhibitory concentration: 490 nM
Estimate against measurement, compound 4: 2.0-fold (0.29 log units) below, and the stated range covers the measured number.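

In this assay, butyl in place of 2,4-difluorophenyl on the sulfonyl sulfur again brings a 4.5-fold lower number from compound 3 to compound 4 (0.65 log units; beyond the scatter) on the core of compound 3, so the change runs the same way on both cores, and its size does not differ measurably between them: the same change on two cores in this assay, a 9.0-fold lower number (0.95 log units; beyond the scatter) from compound 2 to compound 1 and a 4.5-fold lower number (0.65 log units; beyond the scatter) from compound 3 to compound 4, 2.0-fold (0.30 log units) apart, within the scatter of two such steps.

The (dimethylamino)methyl change brings a 3.1-fold higher number from compound 1 to compound 4 (0.49 log units; beyond the scatter) and so passes beyond the scatter only on the butyl compounds, yet this step cannot be told apart from the earlier one: the same change on two cores in this assay, a 1.5-fold higher number (0.18 log units; within the scatter) from compound 2 to compound 3 and a 3.1-fold higher number (0.49 log units; beyond the scatter) from compound 1 to compound 4, 2.0-fold (0.30 log units) apart, within the scatter of two such steps.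

The two changes therefore carry between these cores within the limits of the data, but two pairs show neither that this holds on any other core nor that the size of either step is independent of the other change.

The compounds shown leave open how an ethyl or an unsubstituted phenyl on the sulfonyl sulfur would compare with butyl and 2,4-difluorophenyl. They also leave open whether a morpholine in place of dimethylamino would keep the butyl step.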